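A few compounds are considered here, and "the series" means these few. Any claim that something is new, unique, unknown or untested is made for them only; others in the source may bear on it.

Measured in a physicochemical assay for solubility, read by nephelometry, measured as kinetic solubility, at pH 2; a higher number here means a more soluble compound, a lower number a less soluble compound:
- compound 1 `CC(=O)c1ccc(NC(=O)Nc2ccc(F)c(C(F)(F)F)c2)cc1`: < 1.6 ug/mL
- compound 2 `O=C(Nc1ccc(F)c(C(F)(F)F)c1)Nc1ccccn1`: 1.6 ug/mL
- compound 3 `O=C(Nc1cnccn1)Nc1cnccn1`: 6.3 ug/mL

The entry for compound 1 is a limit and not a number. Of the two actual numbers, the lower belongs to compound 2 at 1.6 ug/mL. Compound 3 stands higher at 6.3 ug/mL, a gap beyond the scatter.

The next compound is compound 4 `O=C(Nc1cccnc1)Nc1ccc(F)c(C(F)(F)F)c1`, which has pyridin-3-yl in place of pyridin-2-yl on an amide-type nitrogen. The two compounds have the same atoms, joined differently. Going by the values given here, no measured pair isolates this change, so any expectation in this assay is a judgement on the structural change alone. A modest rise is expected, only slightly beyond the scatter, and a result close to compound 2 at 1.6 ug/mL would not surprise. The estimated step is a 2.5-fold higher number from compound 2 to compound 4 (0.40 log units; beyond the scatter). For compound 4 the expected value is 4 ug/mL, with an estimated range from 1.6 ug/mL to 12 ug/mL.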

Compound 4, solubility: 50 ug/mL
Compound 4: the middle estimate sits 13-fold (1.10 log units) below what was measured, outside the stated range (above it).
By their numbers in this assay, from the lowest: compound 2; then compound 3; then compound 4.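

Within this assay, pyridin-3-yl in place of pyridin-2-yl on an amide-type nitrogen gives a 31-fold higher number from compound 2 to compound 4 (1.49 log units; beyond the scatter), the first step in the series that isolates a single change. The two compounds have the same atoms, joined differently, and the rest of the structure is shared, so this one change in how the ring is joined accounts for the whole step. The value of compound 2 has the same figure as the limit held by compound 1, so the step could be larger than its printed size: the limit of < 1.6 ug/mL in this assay, at which 1 of the 4 values shown sits.

The compounds shown leave open why this change moves the read-out so far, and whether a similar step would appear on another core. On these data alone, how a ring carrying an amine or a carboxylic acid would read in place of pyridin-3-yl at this position also remains open.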